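Swapping 4-nitrobenzyl for octyl at a single site

The source may report more compounds than this note shows. Statements on the series, on what has been measured and on what is new or still open speak of the compounds shown alone.

Of the compounds shown here, two sharing one core have been tested so far in a functional assay on IMR-32 cells (Homo sapiens) for antiproliferative activity, read by MTT assay; a lower number here means a stronger inhibitor, a higher number a weaker inhibitor. There compound 1 (`CC1(C)CCc2c(ccc(C(=O)/C=C/c3ccc(OCc4cn(-c5ccc(Cl)cc5)nn4)cc3)c2O)O1`) is reported as "not active" (no number reported) while compound 2 (`CC1(C)CCc2c(ccc(C(=O)/C=C/c3ccc(OCc4cn(Cc5ccc([N+](=O)[O-])cc5)nn4)cc3)c2O)O1`) gives 17300 nM as the only figure available, so it cannot be ranked against a second number. Compound 3 (`CCCCCCCCn1cc(COc2ccc(/C=C/C(=O)c3ccc4c(c3O)CCC(C)(C)O4)cc2)nn1`) has yet to be measured. It carries heptyl in place of 4-nitrophenyl on a saturated chain carbon bound to an aromatic nitrogen, which reads equally as 4-nitrobenzyl to octyl. Among the compounds with values here, no measured step shows what such a change does. Within the data shown here, the only anchor is compound 2 at 17300 nM and no shift beyond the scatter is expected in this assay in either direction. The expected step is a 1.2-fold lower number from compound 2 to compound 3 (0.06 log units; within the scatter) and would not count as a real change. The expected value for compound 3 is 15000 nM ( range 5000 nM to 45000 nM) once measured.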

Compound 3, half-maximal inhibitory concentration: "not active" (no number reported)
Compound 3: no number reported; there is nothing to compare the estimate with.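

In this assay, within the data shown here, compound 3 gives "not active" (no number reported) and so yields no readable step from compound 2, the only one of the pair with a number. The compounds shown leave open how far 4-nitrobenzyl to octyl shifts activity. No measurement offers an explanation for this result.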